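The source may hold more compounds than are shown below. What is called first, only, known or untested is meant among the compounds shown, and "the series" means these compounds.

Measured in a functional assay on MCF7 cells (Homo sapiens) for cytotoxicity, read by MTT assay, with a stated time of 72 h; a lower number here means a stronger inhibitor, a higher number a weaker inhibitor:
compound 1 `Cc1ccc(-c2ccc([N+](=O)[O-])cc2)n1-c1ccc(-c2nc3ccc(F)cc3s2)cc1` gives 2370 nM
compound 2 `COc1ccc2nc(-c3ccc(-n4c(C)ccc4-c4ccc(C)cc4)cc3)sc2c1` gives 2850 nM
compound 3 `COc1ccc2nc(-c3ccc(-n4c(C)ccc4-c4ccc(F)cc4)cc3)sc2c1` gives 2800 nM

Compound 3 sits second highest of the three numbers, with compound 2 nearest and compound 1 furthest; both gaps lie within the scatter, so the three values are not separated. Among the measured compounds shown here, the single measured step, a 1.0-fold lower number from compound 2 to compound 3 (0.01 log units; within the scatter), moved nothing beyond the scatter. Compound 4 `COc1ccc2nc(-c3ccc(-n4c(C)ccc4-c4ccc([N+](=O)[O-])cc4)cc3)sc2c1` differs from compound 3 by nitro in place of fluoro on an aromatic carbon. For the measured compounds named here, no measured step covers this exchange on the shared core; compound 1 carries the nitro group but differs elsewhere, and its value lies within the scatter of compound 3. On this basis no step beyond the scatter is expected in this assay, and the estimated step is a 1.1-fold lower number from compound 3 to compound 4 (0.03 log units; within the scatter). Compound 4 is expected at 2600 nM, in the range 1300 nM to 5500 nM.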

Compound 4, half-maximal inhibitory concentration: 4520 nM
Beside the measured number, compound 4's estimate is 1.7-fold (0.24 log units) below it, and the stated range covers the measured number.
By their numbers in this assay, from the lowest: compounds 1, 3, 2 and 4 (each within the scatter of the next).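

In this assay at the aromatic carbon para to a large group, nitro in place of fluoro gives a 1.6-fold higher number from compound 3 to compound 4 (0.21 log units; within the scatter) and nitro in place of methyl gives a 1.6-fold higher number from compound 2 to compound 4 (0.20 log units; within the scatter) so the three groups at this position are not separated. With 4-nitrophenyl held constant, methoxy in place of fluoro on the shared core gives a 1.9-fold higher number from compound 1 to compound 4 (0.28 log units; within the scatter) and this exchange also leaves the values unseparated. No supporting measurement bears on these results.

As far as these compounds go, whether an amine or a carboxylic acid at this position would give a step beyond the scatter remains open.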